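Furan in Place of Thiophene on Compound 1

The compounds below may be only part of what the source reports. "The series", "measured", "known", "first", "only" and "open" are said of these compounds alone.

Compound 1 `Nc1nc(N)c2c(-c3ccsc3)cn([C@@H]3O[C@H](CO)[C@@H](O)[C@H]3O)c2n1` was tested in a functional assay on HepG2 cells (Homo sapiens) for antiproliferative activity, read by XTT assay, with a stated time of 72 h; a higher number here means a weaker inhibitor, a lower number a stronger inhibitor. In this assay compound 1 reached only the limit of > 20000 nM, which is not a number. Compound 2 `Cc1nc(N)c2c(-c3ccsc3)cn([C@@H]3O[C@H](CO)[C@@H](O)[C@H]3O)c2n1`, with methyl in place of amino on an aromatic carbon, likewise stopped at the limit of > 20000 nM. The step that the two limits leave unreadable from compound 1 to compound 2 therefore cannot be read. Compound 3 `Nc1nc2c(c(-c3cc4ccccc4o3)cn2[C@@H]2O[C@H](CO)[C@@H](O)[C@H]2O)c(=O)[nH]1` also gave only the limit of > 20000 nM. Among the compounds with values here, all three values sit at the limit of > 20000 nM in this assay, at which 3 of the 3 values shown sit, so no measured step shows how this assay responds to any change. Compound 4 `Nc1nc(N)c2c(-c3ccoc3)cn([C@@H]3O[C@H](CO)[C@@H](O)[C@H]3O)c2n1` carries furan-3-yl in place of thiophen-3-yl on an aromatic carbon. Within the data shown here, no measured step bears on this swap, so no move beyond the scatter is expected. Compound 4 is therefore estimated at about 30000 nM, within 15000 nM to 100000 nM. This estimate means the step that the limit leaves unreadable from compound 1 to compound 4 is expected to stay within the scatter.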

Compound 4, half-maximal inhibitory concentration: > 20000 nM
Compound 4: no number, only a limit; the forecaster's own chance of this, stated with the estimate: 80%; the middle value does not contradict the limit.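

Compound 1 and compound 4 both give only a limit, so the step between them cannot be read: the limit of > 20000 nM in this assay, at which 4 of the 4 values shown sit. The compounds shown leave open whether furan-3-yl in place of thiophen-3-yl changes anything in this assay, as none gives a number there.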